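Toxicity limits and a 4-methoxyphenyl amide

The source may report more compounds than this note shows. Statements on the series, on what has been measured and on what is new or still open speak of the compounds shown alone.

In a toxicity assay on THP-1 cells (Homo sapiens) for inhibition (on this read-out higher numbers stand for lower toxicity in this test and lower numbers for higher toxicity in this test), compound 3 `COc1ccc(-c2cnc(NC(=O)c3ccncc3)n2C)cc1` gives > 100000 nM as a limit of the assay. Compound 1 `COc1ccc(-c2cnc(NC(=O)c3ccco3)n2C)cc1` gives > 100000 nM as a limit too. Compound 2 `COc1ccc(-c2cnc(NC(=O)c3cccc(Cl)c3)n2C)cc1` gives > 28000 nM as a limit too. The series therefore rests on the limit of > 100000 nM in this assay, at which 2 of the 3 values shown sit, and on the limit of > 28000 nM in this assay, at which 1 of the 3 values shown sits, as its only anchors, and no measured number exists for compound 3.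

Compound 4 `COc1ccc(C(=O)Nc2ncc(-c3ccc(OC)cc3)n2C)cc1` carries 4-methoxyphenyl in place of pyridin-4-yl on a carbonyl carbon, and the change is 4-methoxyphenyl in place of pyridin-4-yl on a carbonyl carbon with the rest of the structure shared.

The measured steps at this same place are a step that the two limits leave unreadable from compound 1 to compound 2 and a step that the two limits leave unreadable from compound 1 to compound 3 and a step that the two limits leave unreadable from compound 2 to compound 3 with no size to carry over. No step beyond the scatter is therefore expected in this assay, and any shift is expected toward lower numbers. The expected step is an at least 1.6-fold lower number from compound 3 to compound 4 (0.22 log units; that floor lies within the scatter) and a limit of the assay is the likely outcome. The estimate for compound 4 is 60000 nM with an expected range of 20000 nM to 100000 nM in this read-out.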

Compound 4, half-maximal cytotoxic concentration: > 100000 nM
Compound 4 was reported as a limit (the forecaster's own chance of this, stated with the estimate: 80%); middle value at least 1.6-fold (0.22 log units) from the limit.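

In this assay compound 4 gives > 100000 nM, a limit of the assay. Steps to compound 4 from compound 1, compound 2 and compound 3 cannot be read, as all four values are limits. The compounds shown leave open how far any of these groups on the carbonyl carbon shifts toxicity.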